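Swapping methoxyphenyl for dibromophenyl on the amide nitrogen

A few compounds are considered here, and "the series" means these few. Any claim that something is new, unique, unknown or untested is made for them only; others in the source may bear on it.

Compound 1 `O=C(COc1ccc2cc(/C=C3/SC(=O)NC3=O)ccc2c1)Nc1ccc(Br)cc1F`: 1900 nM
Compound 2 `Cc1cccc2sc(NC(=O)COc3ccc4cc(/C=C5/SC(=O)NC5=O)ccc4c3)nc12`: 1200 nM
Compound 3 `COc1ccc(NC(=O)COc2ccc3cc(/C=C4/SC(=O)NC4=O)ccc3c2)cc1`: 4700 nM

These three compounds were measured in an assay on isolated protein for inhibition of histone deacetylase 4 (Homo sapiens), with a stated time of 1 h; on this read-out lower numbers stand for stronger inhibition and higher numbers for weaker inhibition. On those numbers compound 3 stands highest of the three: the step of a 2.5-fold higher number from compound 1 to compound 3 (0.39 log units; beyond the scatter) and the step of a 3.9-fold higher number from compound 2 to compound 3 (0.59 log units; beyond the scatter) both run upward, while the step of a 1.6-fold lower number from compound 1 to compound 2 (0.20 log units; within the scatter) stays within the scatter. Compound 4 `O=C(COc1ccc2cc(/C=C3/SC(=O)NC3=O)ccc2c1)Nc1ccc(Br)c(Br)c1` has not yet been measured. It differs from compound 3 in one place: 3,4-dibromophenyl in place of 4-methoxyphenyl on an amide-type nitrogen. Among the compounds with values here, of the measured steps, the one from compound 1 to compound 3 bears most directly on this change, since compound 1 also carries a brominated phenyl on that nitrogen and the step of a 2.5-fold higher number from compound 1 to compound 3 (0.39 log units; beyond the scatter) is of modest size; compound 2 offers the other comparison, with a 3.9-fold higher number from compound 2 to compound 3 (0.59 log units; beyond the scatter) pointing the same way. Replacing the methoxyphenyl by a dibrominated phenyl is therefore expected to lower the number by a modest step, a 2.4-fold lower number from compound 3 to compound 4 (0.37 log units; beyond the scatter), because the step of a 2.5-fold higher number from compound 1 to compound 3 (0.39 log units; beyond the scatter) ran the opposite way. Compound 4 is accordingly estimated at 2000 nM in this assay, with a range from 700 nM to 6000 nM. The range is kept wide because the step of a 1.6-fold lower number from compound 1 to compound 2 (0.20 log units; within the scatter) shows that a change on this nitrogen can also leave the number roughly where it was.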

Compound 4, half-maximal inhibitory concentration: 4900 nM
Beside the measured number, compound 4's estimate is 2.5-fold (0.39 log units) below it, within the range that was stated.
By their numbers in this assay, from the lowest: compounds 2 and 1 (each within the scatter of the next); then compounds 3 and 4 (each within the scatter of the next).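

In this assay the exchange of 4-methoxyphenyl for 3,4-dibromophenyl on the amide-type nitrogen gives a 1.0-fold higher number from compound 3 to compound 4 (0.02 log units; within the scatter), so compound 3 and compound 4 cannot be told apart on this read-out. Bromine on the phenyl ring is therefore not enough to bring the number to that of compound 1: a 2.6-fold higher number from compound 1 to compound 4 (0.41 log units; beyond the scatter) lies beyond the scatter, although both groups are brominated phenyls and differ only in 4-bromo-2-fluorophenyl against 3,4-dibromophenyl. The gap to the fused-ring group is of similar modest size, at a 4.1-fold higher number from compound 2 to compound 4 (0.61 log units; beyond the scatter), but no measurement at hand offers a reason for any of these differences.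

The compounds shown leave open how a phenyl carrying an amine or a carboxylic acid would read on this nitrogen. Also open, on these data alone, is whether an unsubstituted 1,3-benzothiazol-2-yl, without the methyl group of compound 2, would stay with compound 2 or fall with compound 3 and compound 4.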